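Nitrile for Difluorophenyl on the Spiro Amide Carbonyl

The source may hold more compounds than are shown below. What is called first, only, known or untested is meant among the compounds shown, and "the series" means these compounds.

Of the compounds shown here, two have been measured in an ADME assay on stomach for solubility, in simulated gastric fluid (on this read-out lower numbers stand for lower solubility and higher numbers for higher solubility), so far. Compound 2 `O=C(Nc1ccc(C(F)(F)F)cc1)N1CCOC2(CCN(C(=O)c3c(F)cccc3F)CC2)C1` stands at 43 ug/mL in this assay. Compound 1 `O=C(Nc1ccc(C(F)(F)F)cc1)N1CCOC2(CCN(C(=O)c3cccc(Cl)c3)CC2)C1` stands at 26 ug/mL in the same read-out, and the step of a 1.7-fold higher number from compound 1 to compound 2 (0.22 log units; within the scatter) lies within the scatter, so the two compounds cannot be told apart on these numbers. Compound 3 `N#Cc1ccc(C(=O)N2CCC3(CC2)CN(C(=O)Nc2ccc(C(F)(F)F)cc2)CCO3)cc1` has not yet been measured in this assay. It differs from compound 2 in one place: 4-cyanophenyl in place of 2,6-difluorophenyl on a carbonyl carbon. Within the data shown here, the only measured step that bears on this change is the one in which one aryl group replaced another on the same carbonyl carbon, a 1.7-fold higher number from compound 1 to compound 2 (0.22 log units; within the scatter), and that step stayed within the scatter. Nothing measured here separates one aryl group on that carbonyl from another beyond the scatter, so for compound 3 the step of a 1.2-fold lower number from compound 2 to compound 3 (0.09 log units; within the scatter) is expected to stay within the scatter as well. On that basis compound 3 is estimated to give 35 ug/mL in this assay, with a range from 14 ug/mL to 85 ug/mL.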

Compound 3, solubility: 85 ug/mL
The estimate for compound 3 lay 2.4-fold (0.39 log units) below the measured number; measured number inside the range.
By their numbers in this assay, from the lowest: compounds 1, 2 and 3 (each within the scatter of the next, the first and the last beyond it).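

In this assay, among these compounds, the aryl group on this carbonyl carbon now gives a difference that can be read: a 3.3-fold higher number from compound 1 to compound 3 (0.51 log units; beyond the scatter) is the first step at this position to leave the scatter, though only modestly. The other new step, a 2.0-fold higher number from compound 2 to compound 3 (0.30 log units; within the scatter), stays within the scatter, so 4-cyanophenyl is separated from 3-chlorophenyl but not from 2,6-difluorophenyl, and compound 2 cannot be told apart from either compound 1 or compound 3. Nothing at hand accounts for the difference between compound 1 and compound 3.

As far as these compounds go, with a single nitrile-bearing aryl group on the carbonyl, it remains open whether the higher number in compound 3 goes with the nitrile itself or with the loss of the halogens, and whether a pyridine ring, a carboxylic acid or an amine such as a dimethylamino group on the aryl ring would give a step clearly beyond the scatter. From the compounds shown here alone, the trifluoromethyl group and the rest of the core are the same in all three compounds, so what changes there would do to these numbers also stays open.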